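Pyrazole carboxylic acids: N-aryl phenoxy replaced by isopropyl

The source may hold more compounds than are shown below. What is called first, only, known or untested is meant among the compounds shown, and "the series" means these compounds.

Measured so far:
compound 1 `CC(C)Oc1ccc(C(=O)Nc2c(C(=O)O)nn(-c3ccc(Oc4ccccc4)cc3)c2-c2ccc(OC(C)C)cc2)cc1`, 107 nM
compound 2 `CC(C)Oc1ccc(C(=O)Nc2c(C(=O)O)nn(-c3ccc(Oc4ccccc4)cc3)c2-c2ccc(OCc3ccccc3)cc2)cc1`, 4470 nM

Compound 2 gives the higher of the two numbers in an assay for displacement of a labelled ligand from E3 ubiquitin-protein ligase Mdm2 (Homo sapiens), read by fluorescence polarization, with a stated time of 30 min; a lower number here means a stronger inhibitor, a higher number a weaker inhibitor; its nearest neighbour is compound 1, and the step of a 42-fold higher number from compound 1 to compound 2 (1.62 log units; beyond the scatter) arose from benzyl in place of isopropyl on an oxygen on an aromatic ring.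

Compound 3 `CC(C)Oc1ccc(C(=O)Nc2c(C(=O)O)nn(-c3ccc(C(C)C)cc3)c2-c2ccc(OCc3ccccc3)cc2)cc1` is not yet measured. It differs from compound 2 by isopropyl in place of phenoxy on an aromatic carbon. Among the measured compounds shown here, no measured step touches that position; the only step known concerns the oxygen-linked group on the other aromatic ring, so nothing measured bears directly on this change. For the measured compounds named here, with no comparable precedent, the expectation is a step near or modestly beyond the scatter, direction uncertain, a 1.1-fold higher number from compound 2 to compound 3 (0.05 log units; within the scatter). Compound 3 is therefore estimated at 5000 nM, within 1500 nM to 16000 nM.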

Compound 3, inhibition constant: 2190 nM
Compound 3: middle estimate off by 2.3-fold (0.36 log units), on the high side; measured number inside the range.
By their numbers in this assay, from the lowest: compound 1; then compound 3; then compound 2.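

In this assay, among the compounds shown here, isopropyl in place of phenoxy on an aromatic carbon gives a 2.0-fold lower number from compound 2 to compound 3 (0.31 log units; beyond the scatter), the first reading at this position. The position therefore does not need the phenoxy group: with 3 heavy atoms in place of 7, and with the aromatic ring and the hydrogen-bond acceptor of phenoxy gone, the number still moves modestly lower, a much smaller change than a 42-fold higher number from compound 1 to compound 2 (1.62 log units; beyond the scatter) on the oxygen-linked group. No measurement available here accounts for the direction of this step.

Going by these compounds, this reading comes from a single pair carrying benzyl on the oxygen, so it remains open whether the same change holds with isopropyl on that oxygen, as in compound 1. Also open, on these data alone, is how a tert-butyl group or an amine at this position would compare with isopropyl.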